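Compound 3 in the benzoyl ester series: HepG2 estimate

The source may report more compounds than this note shows. Statements on the series, on what has been measured and on what is new or still open speak of the compounds shown alone.

Compound 1 `CC(=O)O[C@@H]1C[C@@H](OC(=O)c2ccccc2)/C(C)=C/[C@H]2[C@@H](OC(=O)c3ccccc3)[C@@H](C)[C@H](OC(=O)c3ccc(Br)cc3)[C@]2(OC(C)=O)[C@H](O)[C@](C)(O)/C=C/C1(C)C` in a functional assay on HepG2 cells (Homo sapiens) for inhibition, read by MTT assay, with a stated time of 48 h; a higher number here means a weaker inhibitor, a lower number a stronger inhibitor: 81300 nM
Compound 2 `CC(=O)O[C@@H]1C[C@@H](OC(=O)c2ccccc2)/C(C)=C/[C@H]2[C@@H](OC(=O)c3ccccc3)[C@@H](C)[C@H](OC(=O)c3ccco3)[C@]2(OC(C)=O)[C@H](O)[C@](C)(O)/C=C/C1(C)C` in this assay: > 150000 nM, a limit and not a number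

Compound 2 stands at the limit of > 150000 nM in this assay, at which 1 of the 2 values shown sits. It therefore has no exact place on the scale of this assay.

Compound 3 `CC(=O)O[C@@H]1C[C@@H](OC(=O)c2ccccc2)/C(C)=C/[C@H]2[C@@H](OC(=O)c3ccccc3)[C@@H](C)[C@H](OC(=O)c3ccccc3)[C@]2(OC(C)=O)[C@H](O)[C@](C)(O)/C=C/C1(C)C` has phenyl in place of furan-2-yl on a carbonyl carbon.

For the measured compounds named here, only one measured step bears on this change: an at least 1.8-fold higher number from compound 1 to compound 2 (0.26 log units; that floor lies within the scatter). That step exchanges 4-bromophenyl for furan-2-yl at a carbonyl carbon, and its floor does not go beyond the scatter, so it gives only weak guidance on size. Phenyl and 4-bromophenyl both bear a six-membered aromatic ring of carbon only, so the expectation for compound 3 leans towards compound 1 at 81300 nM. The expected step is an at least 1.5-fold lower number from compound 2 to compound 3 (0.17 log units; that floor lies within the scatter), towards a lower number and without a large change. A result that is again only a limit remains possible for compound 3.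

The estimate for compound 3 is 100000 nM, with an expected range from 50000 nM to 150000 nM.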

Compound 3, half-maximal inhibitory concentration: > 150000 nM
Compound 3 was reported as a limit; the forecaster's own chance of this, stated with the estimate: 30%; middle value at least 1.5-fold (0.17 log units) away from the limit.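

In this assay compound 3 gives > 150000 nM, a limit and not a number. Hydrogen in place of bromo on an aromatic carbon gives an at least 1.8-fold higher number from compound 1 to compound 3 (0.26 log units; that floor lies within the scatter), so the plain benzoyl ester adds a second comparison with compound 1, but neither this floor nor the one for furan-2-yl shows a change beyond the scatter. The change from furan-2-yl to phenyl itself cannot be read, and compound 1 remains the only one of the three with an exact place on the scale, while the other two share one limit: the limit of > 150000 nM in this assay, at which 2 of the 3 values shown sit.

From the compounds shown here alone, how far compound 2 and compound 3 lie beyond that limit stays unknown, so neither the furan-2-yl to phenyl exchange nor the loss of bromo can yet be given a size. Also open, going by these compounds, is whether another group on the same aromatic carbon, such as an amine, a carboxylic acid or a longer alkyl chain, would give a reading in this assay clearly apart from compound 1.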